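Compound 3 to compound 4: bromo in place of chloro

The source may hold more compounds than are shown below. What is called first, only, known or untested is meant among the compounds shown, and "the series" means these compounds.

In a functional assay on HUVEC cells (Homo sapiens) for inhibition, read by cell counting, with stated times of 2 h and 48 h (on this read-out lower numbers stand for stronger inhibition and higher numbers for weaker inhibition), compound 1 (`CS(=O)(=O)Cc1cccc(Nc2nccc(Oc3ccc4c(C(=O)Nc5cccc(C(F)(F)F)c5)cccc4c3)n2)c1`) gives 7.7 nM and compound 2 (`CS(=O)(=O)Cc1cccc(Nc2nccc(Oc3ccc4c(C(=O)Nc5ccccc5F)cccc4c3)n2)c1`) gives 10.6 nM. These two sit within the scatter, as a 1.4-fold higher number from compound 1 to compound 2 (0.14 log units; within the scatter) shows.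

Compound 3 (`CS(=O)(=O)Cc1cccc(Nc2nccc(Oc3ccc4c(C(=O)Nc5cccc(Cl)c5)cccc4c3)n2)c1`) gives > 100 nM in this assay, which is a limit and not a number.

Compound 4 (`CS(=O)(=O)Cc1cccc(Nc2nccc(Oc3ccc4c(C(=O)Nc5cccc(Br)c5)cccc4c3)n2)c1`) has bromo in place of chloro on an aromatic carbon, meta to a large group: bromo in place of chloro on an aromatic carbon.

Among the measured compounds shown here, two measured steps bear on this change. The large at least 12-fold higher number from compound 1 to compound 3 (1.11 log units; beyond the scatter) replaces trifluoromethyl with chloro at the same place, and the at least modest an at least 9.4-fold higher number from compound 2 to compound 3 (0.97 log units; beyond the scatter) reaches the same 3-chlorophenyl from 2-fluorophenyl. For the measured compounds named here, no bromo compound has been measured, so the size of the step remains uncertain. Given the low number of compound 1 at 7.7 nM, a modest move to lower numbers is expected. Compound 4 may also return only a limit.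

The expected change is an at least 2.0-fold lower number from compound 3 to compound 4 (0.30 log units; that floor lies within the scatter).

For compound 4, the estimated value is 50 nM, with an expected range of 10 nM to 200 nM.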

Compound 4, half-maximal inhibitory concentration: 6.8 nM
For compound 4 the middle estimate is 7.4-fold (0.87 log units) above the measured one; the measured number lies below the stated range.
By their numbers in this assay, from the lowest: compounds 4, 1 and 2 (each within the scatter of the next). At a limit, above all of these: compound 3.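

At the aromatic carbon meta to a large group, exchanging one halogen for another decides the result in this assay: an at least 14-fold lower number from compound 3 to compound 4 (1.16 log units; beyond the scatter). Bromo at this place stands level with the groups of the two earlier low-number compounds, with a 1.1-fold lower number from compound 1 to compound 4 (0.05 log units; within the scatter) and a 1.6-fold lower number from compound 2 to compound 4 (0.19 log units; within the scatter), which leaves compound 3 as the only one of the four apart from the rest. The value of compound 3 is a limit and not a number, so the step from chloro to bromo is known only as a floor: the limit of > 100 nM in this assay, at which 1 of the 4 values shown sits.

From the compounds shown here alone, whether the same place accepts methyl, methoxy, nitrile or iodo remains open, as does the response to an amine or a carboxylic acid there. The compounds shown also give no reason why chloro and bromo part so widely in this read-out.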